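From 2-bromophenyl to 4-fluorobenzyl on the sulfonyl sulfur

A few compounds are considered here, and "the series" means these few. Any claim that something is new, unique, unknown or untested is made for them only; others in the source may bear on it.

Of the compounds shown here, two have been measured so far in a functional assay on DU-145 cells (Homo sapiens) for inhibition, read by trypan blue exclusion, with a stated time of 96 h; on this read-out higher numbers stand for weaker inhibition of growth and lower numbers for stronger inhibition of growth. In this assay, compound 1 (`CN(C)c1ccc(/C=C(\C(=O)c2ccc(Br)cc2)S(=O)(=O)Cc2ccc(F)cc2)cc1`) gives 50000 nM. Compound 2 (`O=C(/C(=C\c1ccc(Br)cc1)S(=O)(=O)c1ccccc1Br)c1ccc(Br)cc1`) gives 1000 nM and holds the lower of the two numbers, with a gap to compound 1 that lies beyond the scatter.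

The next entry is compound 3 (`O=C(/C(=C\c1ccc(Br)cc1)S(=O)(=O)Cc1ccc(F)cc1)c1ccc(Br)cc1`). It differs from compound 2 at one place, where 4-fluorobenzyl stands in place of 2-bromophenyl on a sulfonyl sulfur (4-fluorobenzyl in place of 2-bromophenyl on a sulfonyl sulfur). For the measured compounds named here, no measured pair isolates this change, so its size cannot be read directly from the data. Compound 1 also carries 4-fluorobenzyl on a sulfonyl sulfur and gives 50000 nM, but it differs from compound 2 in more than this one place and offers only weak guidance. A moderate loss of growth inhibition therefore seems more likely than a gain, with considerable uncertainty. The expected change is a 3.0-fold higher number from compound 2 to compound 3 (0.48 log units; beyond the scatter), a step toward weaker inhibition of growth. For compound 3 the estimated value is 3000 nM, with an expected range from 500 nM to 20000 nM.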

Compound 3, concentration for 50% growth inhibition: 25000 nM
The estimate for compound 3 lay 8.3-fold (0.92 log units) below the measured number; measured number above the stated range.
By their numbers in this assay, from the lowest: compound 2; then compounds 3 and 1 (each within the scatter of the next).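

In this assay, for the compounds shown here, the sulfonyl sulfur proves to be a position of large effect: 4-fluorobenzyl in place of 2-bromophenyl gives a 25-fold higher number from compound 2 to compound 3 (1.40 log units; beyond the scatter) and provides the first reading of a single change at this place. With 4-fluorobenzyl held on the sulfonyl sulfur, bromo in place of dimethylamino on an aromatic carbon gives a 2.0-fold lower number from compound 1 to compound 3 (0.30 log units; within the scatter) and so does not separate the two compounds, which leaves both 4-fluorobenzyl compounds well short of compound 2 in growth inhibition. Nothing at hand accounts for the size of the step at the sulfonyl sulfur.

The step from 2-bromophenyl to 4-fluorobenzyl alters both the ring substituent and the link to the sulfur, so the compounds shown leave open whether plain benzyl or plain phenyl on the sulfonyl sulfur would stand with compound 2 or with compound 3. Also open, from the compounds shown here alone, is how an amine or a carboxylic acid on a longer chain at this place would read out in this assay, and whether the dimethylamino-to-bromo step stays as small with 2-bromophenyl on the sulfur.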